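The source may hold more compounds than are shown below. What is called first, only, known or untested is meant among the compounds shown, and "the series" means these compounds.

Measured compounds: compound 1 `COc1ccc(NC(=O)c2cc3ccccc3oc2=O)cc1OC`, compound 2 `COc1ccc(NC(=O)c2cc3ccc(OCc4ccccc4)cc3oc2=O)cc1OC`, compound 3 `Cc1cccc(Cl)c1NC(=O)c1cc2ccc(OCc3ccc(F)cc3)cc2oc1=O`.

In an in vitro assay on BTI-TN-5B1-4 cells for inhibition of Amine oxidase [flavin-containing] B (Homo sapiens), read by fluorescence (on this read-out higher numbers stand for weaker inhibition and lower numbers for stronger inhibition), compound 1 gives 860 nM, compound 2 gives 4390 nM and compound 3 gives 41600 nM, the highest of the three numbers; the gaps from compound 3 down to compound 2 and to compound 1 both lie beyond the scatter.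

Compound 4 `COc1ccc(NC(=O)c2cc3ccc(OCc4ccc(F)cc4)cc3oc2=O)cc1OC` arises from compound 3 by 3,4-dimethoxyphenyl in place of 2-chloro-6-methylphenyl on an amide-type nitrogen. Going by the values given here, no measured step covers this change on the amide nitrogen; the only measured step, a 5.1-fold higher number from compound 1 to compound 2 (0.71 log units; beyond the scatter), concerns the aromatic carbon instead. Compound 2 carries the same 3,4-dimethoxyphenyl on its amide nitrogen and sits far below compound 3, so a drop beyond the scatter is expected for a 9.2-fold lower number from compound 3 to compound 4 (0.97 log units; beyond the scatter).

Compound 4 is therefore estimated at 4500 nM, within 1500 nM to 14000 nM.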

Compound 4, half-maximal inhibitory concentration: 2870 nM
For compound 4 the middle estimate is 1.6-fold (0.20 log units) above the measured one; the range from low to high includes it.
By their numbers in this assay, from the lowest: compound 1; then compounds 4 and 2 (each within the scatter of the next); then compound 3.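

Going by these compounds alone, on the amide nitrogen, 3,4-dimethoxyphenyl in place of 2-chloro-6-methylphenyl gives the first measured step at this position, a large one (a 14-fold lower number from compound 3 to compound 4 (1.16 log units; beyond the scatter)). Fluoro in place of hydrogen on an aromatic carbon changes nothing beyond the scatter (a 1.5-fold lower number from compound 2 to compound 4 (0.18 log units; within the scatter)), while (4-fluorobenzyl)oxy added to the core of compound 1 still points the same way as benzyloxy (a 3.3-fold higher number from compound 1 to compound 4 (0.52 log units; beyond the scatter)). Nothing measured here explains these steps.

As far as these compounds go, how 2-chloro-6-methylphenyl behaves on the core of compound 1 remains open, as does a carboxylic acid or an amine on the amide's phenyl ring.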